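A few compounds are considered here, and "the series" means these few. Any claim that something is new, unique, unknown or untested is made for them only; others in the source may bear on it.

Compound 1 `CN1CCN(c2ncc3cc(Cl)ccc3n2)CC1` is the parent of this small series. Among the compounds with values here, in an assay on HEK293 cells for displacement of a labelled ligand from 5-hydroxytryptamine receptor 3A (Homo sapiens), read by scintillation counting, with a stated time of 24 h, in the presence of a further agent that is not named here (a higher number here means a weaker inhibitor, a lower number a stronger inhibitor), compound 1 gives 7.41 nM, which is the second highest of the three numbers measured so far. Its nearest neighbour is compound 2 `CN1CCN(c2nc(N(C)C)c3cc(Cl)ccc3n2)CC1`, where a dimethylamino replaces a hydrogen on an aromatic carbon; compound 2 gives 6.61 nM, and the step of a 1.1-fold lower number from compound 1 to compound 2 (0.05 log units; within the scatter) is within the scatter. The furthest is compound 3 `CN1CCN(c2nc(NCC3CCCCC3)c3cc(Cl)ccc3n2)CC1`, carrying a (cyclohexylmethyl)amino in place of that hydrogen; compound 3 gives 16600 nM, and the step of a 2200-fold higher number from compound 1 to compound 3 (3.35 log units; beyond the scatter) is large, as is a 2500-fold higher number from compound 2 to compound 3 (3.40 log units; beyond the scatter).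

Compound 4 `CN1CCN(c2ncc3ccccc3n2)CC1` differs from compound 1 in another place: hydrogen in place of chloro on an aromatic carbon. Within the data shown here, none of the measured steps touches the chloro; all of them alter the substituent on a different aromatic carbon, so there is no direct precedent for this change. Among the measured compounds shown here, the only guidance is that the core tolerated a small group there without loss, while a large one cost much, which says nothing about removing the chloro. A modest step is therefore expected, most likely toward a higher number, with the direction uncertain. The expected step of a 2.7-fold higher number from compound 1 to compound 4 (0.43 log units; beyond the scatter) reflects this. Compound 4 is expected to give 20 nM, with a range from 5 nM to 80 nM.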

Compound 4, inhibition constant: 1.35 nM
Compound 4: middle estimate off by 15-fold (1.17 log units), on the high side; measured number outside the range, below it.
By their numbers in this assay, from the lowest: compound 4; then compounds 2 and 1 (each within the scatter of the next); then compound 3.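

With hydrogen in place of chloro on the six-membered aromatic ring of carbon only, the number in this assay falls (a 5.5-fold lower number from compound 1 to compound 4 (0.74 log units; beyond the scatter)), so the low numbers of this series do not depend on that chlorine atom, and compound 1 is in fact the weaker of the pair. The earlier steps all concerned a different aromatic carbon, where dimethylamino made no difference beyond the scatter (a 1.1-fold lower number from compound 1 to compound 2 (0.05 log units; within the scatter)) and (cyclohexylmethyl)amino brought a large loss (a 2200-fold higher number from compound 1 to compound 3 (3.35 log units; beyond the scatter)); the present step is the only one shown that lowers the number beyond the scatter. Nothing measured here accounts for this gain on losing the chloro.

As far as these compounds go, it remains open whether fluoro, bromo, methyl or methoxy at this place would give a number nearer that of compound 4 or that of compound 1, and whether chloro elsewhere on the same ring would behave as it does here. Also open is whether the gain from hydrogen here would carry over to a core bearing dimethylamino, as in compound 2, since the two changes are not shown together.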